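The source may report more compounds than this note shows. Statements on the series, on what has been measured and on what is new or still open speak of the compounds shown alone.

In a functional assay on NALM-6 cells (Homo sapiens) for cytotoxicity, read by luminescence and CellTiter-Glo, with a stated time of 3 days (on this read-out higher numbers stand for weaker inhibition and lower numbers for stronger inhibition), compound 1 (`O=C(Nc1ccc(Cl)cc1Cl)c1cc(F)ccc1O`) gives 1620 nM and compound 2 (`N#Cc1ccc(NC(=O)c2ccc3cccnc3c2O)c(F)c1`) gives 370 nM as the lower of the two numbers, a gap beyond the usual scatter. Compound 3 (`N#Cc1ccc(NC(=O)c2ccc3cccnc3c2O)c(C#N)c1`) is still unmeasured. It has cyano in place of fluoro on an aromatic carbon, ortho to a large group and meta to a cyano group. Among the compounds with values here, no measured pair shows this swap, so the expectation is loose: a small move toward weaker inhibition, within the scatter, is expected (a 1.4-fold higher number from compound 2 to compound 3 (0.13 log units; within the scatter)). Compound 3 is estimated at 500 nM (expected range 150 nM to 1600 nM).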

Compound 3, half-maximal inhibitory concentration: 350 nM
Compound 3: the middle estimate sits 1.4-fold (0.15 log units) above what was measured, within the range that was stated.
By their numbers in this assay, from the lowest: compounds 3 and 2 (each within the scatter of the next); then compound 1.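

In this assay cyano in place of fluoro on this aromatic carbon, ortho to a large group, gives a 1.1-fold lower number from compound 2 to compound 3 (0.02 log units; within the scatter) and so leaves the two compounds indistinguishable. This carbon therefore accepts a group of two heavy atoms with a hydrogen-bond acceptor as well as it accepts a single fluorine, something compound 1 and compound 2 alone could not show. No measurement here accounts for this result. From the compounds shown here alone, whether an amine or a methoxy group on this same carbon would be accepted equally well remains open.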